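Methyl in place of bromo: from compound 3 to compound 4

The compounds below may be only part of what the source reports. "The series", "measured", "known", "first", "only" and "open" are said of these compounds alone.

Of the compounds shown here, three sharing one core have been measured in a physicochemical assay for acid dissociation, using potentiometric titration. Compound 1 `CCC/N=C1\S/C(=C\c2ccc(O)cn2)C(=O)N1c1ccccc1C` gives 7.1, compound 2 `CCC/N=C1\S/C(=C\c2ccc(O)cc2)C(=O)N1c1ccccc1C` gives 8.3, and compound 3 `CCC/N=C1\S/C(=C\c2ccc(O)c(Br)c2)C(=O)N1c1ccccc1C` gives 6.4, the lowest of the three. Its nearest neighbour sets a modest gap: a number 0.70 log units lower from compound 1 to compound 3 (beyond the scatter).

Compound 4 `CCC/N=C1\S/C(=C\c2ccc(O)c(C)c2)C(=O)N1c1ccccc1C` is still unmeasured. It carries methyl in place of bromo on an aromatic carbon, ortho to a hydroxy group (methyl in place of bromo on an aromatic carbon). The measured step that bears most directly on this change is the one that introduced the bromo: a number 1.90 log units lower from compound 2 to compound 3 (beyond the scatter). The step of a number 1.20 log units higher from compound 1 to compound 2 (beyond the scatter) concerns a different change and offers little guidance. For the measured compounds named here, no measured compound carries the methyl group, so its own contribution in this assay remains unknown. Removing the bromo is expected to reverse roughly all of the large step seen with compound 3, and the expected change is a large rise: a number 2.00 log units higher from compound 3 to compound 4 (beyond the scatter). For compound 4 the estimated value is 8.4, within an expected range of 8 to 8.8.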

Compound 4, acid dissociation constant: 8.5
Beside the measured number, compound 4's estimate is 0.10 log units below it, and the stated range covers the measured number.
By their numbers in this assay, from the lowest: compound 3; then compound 1; then compounds 2 and 4 (each within the scatter of the next).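

In this assay, methyl gets its first reading at this position, ortho to a hydroxy group: set against hydrogen on the same aromatic carbon (a number 0.20 log units higher from compound 2 to compound 4 (within the scatter)), it cannot be told apart, whereas set against bromo it shows a large step (a number 2.10 log units higher from compound 3 to compound 4 (beyond the scatter)). Among these three groups, then, bromo alone stands apart at this position, and methyl does not carry the large step in the opposite direction. The 4-hydroxy-3-methylphenyl group also stands well apart from 5-hydroxypyridin-2-yl (a number 1.40 log units higher from compound 1 to compound 4 (beyond the scatter)), though no evidence here explains any of these numbers.

The compounds shown leave open how a chloro or a methoxy group on this aromatic carbon would read in this assay. Also open, as far as these compounds go, is whether bromo or methyl would shift the number in the same way on the 5-hydroxypyridin-2-yl group.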